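The compounds below may be only part of what the source reports. "The series", "measured", "known", "first", "only" and "open" are said of these compounds alone.

Three compounds from one series have been examined in a functional assay on MDA-MB-435 cells (Homo sapiens) for inhibition, read by sulforhodamine B assay, with a stated time of 48 h; a higher number here means a weaker inhibitor of growth, a lower number a stronger inhibitor of growth. Compound 1 `Nc1cc(N)c2nc(-c3ccccc3)c(Oc3ccc(Cl)c(Cl)c3)nc2c1` gives 20900 nM. Compound 2 `Nc1cc(N)c2nc(-c3ccccc3)c(NCc3ccc(Cl)c(Cl)c3)nc2c1` gives 7590 nM, a lower number than compound 1 by a gap beyond the usual scatter, so compound 2 is the stronger growth inhibitor of the two. Compound 3 `CCOC(=O)[C@H](CCC(=O)O)NC(=O)c1ccc(Sc2nc3cc(N)cc(N)c3nc2-c2ccccc2)cc1` gives 33900 nM; its number and that of compound 1 lie within the scatter of each other, so no order can be read between them. Compound 1 thus sits with the second highest number of the three.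

The next compound, compound 4 `Nc1cc(N)c2nc(-c3ccccc3)c(Sc3ccc(F)cc3)nc2c1`, differs from compound 1 in one place: (4-fluorophenyl)sulfanyl in place of 3,4-dichlorophenoxy on an aromatic carbon. Within the data shown here, no measured pair shows this exact change, so the size of its effect is unknown. Compound 3, which also carries a sulfur-linked aryl group, gives 33900 nM, but it bears a much larger group, so it is a weak guide. The step from compound 1 to compound 4 is expected to be small, a 1.4-fold lower number from compound 1 to compound 4 (0.14 log units; within the scatter), not clearly beyond the scatter in either direction. Compound 4 is estimated at 15000 nM, within a range from 5000 nM to 45000 nM.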

Compound 4, concentration for total growth inhibition: 33100 nM
Compound 4: the middle estimate sits 2.2-fold (0.34 log units) below what was measured, within the range that was stated.
By their numbers in this assay, from the lowest: compound 2; then compounds 1, 4 and 3 (each within the scatter of the next).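

In this assay, putting (4-fluorophenyl)sulfanyl in place of 3,4-dichlorophenoxy on this aromatic carbon gives a 1.6-fold higher number from compound 1 to compound 4 (0.20 log units; within the scatter) and so no order can be read between the two compounds. Among these compounds, this is the first direct comparison at this position, and it shows that this exchange of one aryl group for another, with a new linking atom and different halogens, leaves the number in the same range. The linking atom and the halogens change together, so this single step cannot separate their effects, and no measurement at hand offers an explanation for the result.

The compounds shown leave open whether either change alone would matter. They also leave open how the number would respond to a group without an aryl ring at this carbon, such as a morpholine or a butyl chain.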